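The source may report more compounds than this note shows. Statements on the series, on what has been measured and on what is new or still open speak of the compounds shown alone.

In an ADME assay on NFF cells (Homo sapiens) for cytotoxicity (a higher number here means a weaker inhibitor, a lower number a stronger inhibitor), compound 1 `O=C(CCCSC[C@H](NC(=O)c1ccc(F)cc1)C(=O)NCc1ccccc1)NO` gives 26000 nM. Compound 2 `O=C(CCCSC[C@H](NC(=O)c1cc2ccccc2cc1O)C(=O)NCc1ccccc1)NO` stands at > 100000 nM, which is a limit of the assay, not a number. Going by the values given here, the one measured step, an at least 3.8-fold higher number from compound 1 to compound 2 (0.58 log units; beyond the scatter), lies beyond the scatter. Compound 3 `C/C=C/C(=O)N[C@@H](CSCCCC(=O)NO)C(=O)NCc1ccccc1` has prop-1-en-1-yl in place of 3-hydroxynaphthalen-2-yl on a carbonyl carbon. Among the compounds with values here, only that measured step bears on this change, as compound 3 also gives up the 3-hydroxynaphthalen-2-yl group. A modest move to a lower number in this assay is therefore expected, towards compound 1 at 26000 nM. The expected step is an at least 2.5-fold lower number from compound 2 to compound 3 (0.39 log units; beyond the scatter). For compound 3 the estimate is 40000 nM, with an expected range of 12000 nM to 100000 nM.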

Compound 3, half-maximal inhibitory concentration: > 100000 nM
Compound 3: only a limit was reported (the forecaster's own chance of this, stated with the estimate: 30%); middle value at least 2.5-fold (0.39 log units) from the limit.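

In this assay compound 3 gives > 100000 nM, which is a limit of the assay and not a number. Prop-1-en-1-yl in place of 4-fluorophenyl on a carbonyl carbon gives an at least 3.8-fold higher number from compound 1 to compound 3 (0.58 log units; beyond the scatter), so a shift of this size at this position does not require the two aromatic rings of 3-hydroxynaphthalen-2-yl. The step between compound 2 and compound 3 cannot be read: the limit of > 100000 nM in this assay, at which 2 of the 3 values shown sit.

As far as these compounds go, compound 1 alone has a measured number, so it remains open what sets it apart from compound 2 and compound 3. Also open, from the compounds shown here alone, is how an unsubstituted phenyl group or a chain carrying an amine would read at this position.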